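The source may report more compounds than this note shows. Statements on the series, on what has been measured and on what is new or still open speak of the compounds shown alone.

Compound 1 `COc1cc(-c2cc(/C=C/C(=O)c3ccc(N)cc3)[nH]n2)cc(OC)c1OC` gives 1710 nM in a functional assay on NCI-H226 cells (Homo sapiens) for inhibition, read by sulforhodamine B assay, with a stated time of 48 h; a higher number here means a weaker inhibitor of growth, a lower number a stronger inhibitor of growth. Going by the values given here, compound 2 `COc1cc(-c2cc(/C=C/C(=O)c3ccc(Cl)c(Cl)c3)[nH]n2)cc(OC)c1OC` gives 18600 nM in this assay, the higher of the two numbers measured so far; the step of an 11-fold higher number from compound 1 to compound 2 (1.04 log units; beyond the scatter) is the only one available. Compound 3 `COc1ccc(C(=O)/C=C/c2cc(-c3cc(OC)c(OC)c(OC)c3)n[nH]2)cc1OC` differs from compound 2 in one place: 3,4-dimethoxyphenyl in place of 3,4-dichlorophenyl on a carbonyl carbon.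

Among the compounds with values here, the one measured step bears on this change only indirectly, since it shows that swapping the aromatic group on the carbonyl carbon can move the number a long way, with the dichlorophenyl giving the higher value. The dimethoxyphenyl brings hydrogen-bond acceptors that the dichlorophenyl lacks, which is the same direction of change as the amine of compound 1, so a lower number than compound 2 is expected, though of uncertain size. Compound 3 is therefore estimated at 6000 nM, between 1800 nM and 20000 nM, an expected step of a 3.1-fold lower number from compound 2 to compound 3 (0.49 log units; beyond the scatter).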

Compound 3, concentration for 50% growth inhibition: 1690 nM
Compound 3: middle estimate off by 3.6-fold (0.55 log units), on the high side; measured number outside the range, below it.
By their numbers in this assay, from the lowest: compounds 3 and 1 (each within the scatter of the next); then compound 2.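

In this assay, replacing 3,4-dichlorophenyl on the carbonyl carbon with 3,4-dimethoxyphenyl gives an 11-fold lower number from compound 2 to compound 3 (1.04 log units; beyond the scatter) and so brings the number back to the level of compound 1. That level is therefore not tied to the 4-aminophenyl group, since two differently substituted rings cannot be told apart here, with a 1.0-fold lower number from compound 1 to compound 3 (0.01 log units; within the scatter) as their step. Among these three compounds, 3,4-dichlorophenyl is the only group that stands apart, while the amine and the two methoxy groups give matching numbers.

As far as these compounds go, it remains open whether a single methoxy group, a hydroxyl group, a carboxylic acid or a single chlorine on this ring would give the lower or the higher level. No measurement at hand gives a cause for either large step.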